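The compounds below may be only part of what the source reports. "The series", "measured", "known", "first", "only" and "open" are said of these compounds alone.

Compound 1, `O=C(Nc1cccc(-n2cc(-c3ccncc3)c(-c3ccc(Cl)c(O)c3)n2)c1)Nc1ccc(Cl)c(Cl)c1`, and compound 2, `O=C(Nc1cccc(-n2cc(-c3ccncc3)c(-c3ccc(Cl)c(O)c3)n2)c1)Nc1cc(C(F)(F)F)cc(C(F)(F)F)c1`, share the same core and differ only in the ring at one end of it. In a functional assay on NCI-H460 cells (Homo sapiens) for inhibition, read by sulforhodamine B assay, with a stated time of 48 h (on this read-out lower numbers stand for stronger inhibition of growth and higher numbers for weaker inhibition of growth), compound 1 gives 3570 nM, the highest number of the two measured. Compound 2 gives 1480 nM, a lower number that lies beyond the usual scatter, so compound 2 inhibits growth more strongly than compound 1. Compound 3, `O=C(Nc1cccc(-n2cc(-c3ccncc3)c(-c3ccc(Cl)c(O)c3)n2)c1)Nc1ccc(Cl)c(C(F)(F)F)c1`, has not been measured yet. It differs from compound 1 by trifluoromethyl in place of chloro on an aromatic carbon. For the measured compounds named here, the only hint comes from compound 2, which carries trifluoromethyl groups on that ring and gives the lower number 1480 nM. A modest step toward a lower number, a 1.6-fold lower number from compound 1 to compound 3 (0.21 log units; within the scatter), is therefore expected, though a result within the scatter of compound 1 would not be surprising. Compound 3 is estimated at 2200 nM, with a likely range from 1000 nM to 4800 nM.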

Compound 3, concentration for total growth inhibition: 4000 nM
Compound 3: middle estimate off by 1.8-fold (0.26 log units), on the low side; the measured number falls inside the stated range.
By their numbers in this assay, from the lowest: compound 2; then compounds 1 and 3 (each within the scatter of the next).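

In this assay the exchange of chloro for trifluoromethyl, on an aromatic carbon ortho to a chloro group, gives a 1.1-fold higher number from compound 1 to compound 3 (0.05 log units; within the scatter) and so the two compounds cannot be told apart at this position. For the compounds shown here, compound 2 differs from compound 1 in more than one place on that ring, so only this new pair shows the single exchange on its own. No measurement is available that would explain this result.

On these data alone, what other groups at this position would do remains open, for example fluoro, methyl, methoxy, nitrile or an amine. It is also unknown whether the same exchange would give a similar result if the neighbouring chloro group were replaced by another group.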